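The source may report more compounds than this note shows. Statements on the series, on what has been measured and on what is new or still open speak of the compounds shown alone.

Three compounds have been measured in an ADME assay on Vero cells (Chlorocebus sabaeus) for cytotoxicity, read by resazurin assay, with a stated time of 72 h; on this read-out higher numbers stand for weaker inhibition and lower numbers for stronger inhibition:

Compound 1, `O=C(CCN1CCN(c2ccc(F)cc2)CC1)c1ccc(Cl)c(F)c1`, gives 105000 nM.
Compound 2, `O=C(CCN1CCN(c2ccc(C(F)(F)F)cc2)CC1)c1ccc(Cl)c(F)c1`, gives 74300 nM.
Compound 3, `O=C(CCN1CCN(c2ccc(F)cc2)CC1)c1ccc(OC(F)(F)F)cc1`, gives 70300 nM.

Compound 1 and compound 2 share a core and differ in one place: trifluoromethyl in place of fluoro on an aromatic carbon. In this assay this change made a 1.4-fold lower number from compound 1 to compound 2 (0.15 log units; within the scatter), so the two compounds cannot be told apart on this read-out. Compound 3 carries a different core from compound 1; the difference between the two cores is not broken down here. What the values show is that compound 3 and compound 1, and compound 3 and compound 2, all lie close together in this assay.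

Compound 4, `O=C(CCN1CCN(c2ccc(C(F)(F)F)cc2)CC1)c1ccc(OC(F)(F)F)cc1`, has not yet been measured. It is related to compound 3 in the same way that compound 2 is related to compound 1: trifluoromethyl in place of fluoro on an aromatic carbon. The place is the same in both pairs, so this is the same change made on a second core.

Among the measured compounds shown here, the only guide for compound 4 is the earlier pair. A small step is expected from compound 3 because a 1.4-fold lower number from compound 1 to compound 2 (0.15 log units; within the scatter) was itself small on the first core. The step that the estimate means is a 1.3-fold lower number from compound 3 to compound 4 (0.11 log units; within the scatter), expected to stay inside the usual scatter. On that basis compound 4 is estimated at 55000 nM, with a likely range from 30000 nM to 110000 nM.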

Compound 4, half-maximal inhibitory concentration: 64900 nM
For compound 4 the middle estimate is 1.2-fold (0.07 log units) below the measured one; measured number inside the range.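

In this assay, trifluoromethyl in place of fluoro on the second core gives a 1.1-fold lower number from compound 3 to compound 4 (0.03 log units; within the scatter), so this pair, like the first, cannot be told apart on this read-out. Set side by side, the two steps show no difference that can be read: the same change on two cores in this assay, a 1.4-fold lower number (0.15 log units; within the scatter) from compound 1 to compound 2 and a 1.1-fold lower number (0.03 log units; within the scatter) from compound 3 to compound 4, 1.3-fold (0.12 log units) apart, within the scatter of two such steps. Among the compounds shown here, this shows that, in these two pairs, the change carries from one core to the other as a step too small to read; it does not show that the change has any real effect on this read-out, since a step inside the usual scatter cannot be separated from no step at all, and two cores say nothing about how the change would behave on a third.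

What the compounds shown leave open is whether a different group on the same aromatic carbon, such as an amine, a carboxylic acid or a nitrile, would give a step large enough to read beyond the scatter. From the compounds shown here alone, it also remains open whether trifluoromethyl in place of fluoro would stay this small on a core with a longer chain leading to the carbonyl.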